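Swapping the Aromatic Amine Substituent in Compound 1

The compounds below may be only part of what the source reports. "The series", "measured", "known", "first", "only" and "open" are said of these compounds alone.

Measured compounds:
compound 1 `Nc1cccc(Nc2c(C(=O)NCc3ccc(F)cc3)nc(Br)c3cccnc23)c1`: 8000 nM
compound 2 `C[C@H](NC(=O)c1nc(Br)c2cccnc2c1N[C@H]1CC[C@H](N)CC1)c1ccc(F)cc1`: > 10000 nM, a limit of the assay rather than a number
compound 3 `N[C@H]1CC[C@H](Nc2c(C(=O)NCc3cccs3)nc(Br)c3cccnc23)CC1`: 4100 nM

The read-out is a functional assay on MDA-MB-435 cells (Homo sapiens) for cytotoxicity, read by MTT assay, with a stated time of 72 h; on this read-out higher numbers stand for weaker inhibition and lower numbers for stronger inhibition. Compound 1 holds the higher of the two numbers given, and its gap to compound 3 lies within the scatter. Compound 2 reaches only (the limit of > 10000 nM in this assay, at which 1 of the 3 values shown sits).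

Compound 4 `O=C(NCc1ccc(F)cc1)c1nc(Br)c2cccnc2c1NCc1ccccc1` differs from compound 1 by benzyl in place of 3-aminophenyl on a nitrogen on an aromatic ring. For the measured compounds named here, the single measured step, an at least 2.4-fold lower number from compound 2 to compound 3 (0.38 log units; beyond the scatter), changes a group on an amide-type nitrogen and so does not bear on this change. Going by the values given here, no measured pair varies the group on the nitrogen on the aromatic ring, so no step beyond the scatter is expected. Compound 4 is therefore estimated at 8000 nM, within 3000 nM to 20000 nM. The expected step is thus no change at the digits printed from compound 1 to compound 4 (within the scatter).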

Compound 4, half-maximal inhibitory concentration: > 20000 nM
Compound 4: a limit, no number; the forecaster's own chance of this, stated with the estimate: 30%; middle value at least 2.5-fold (0.39 log units) away from the limit.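

For the compounds shown here, this is the first measured step at this position, and it shows that the group on the nitrogen on the aromatic ring matters in this assay. Putting benzyl in place of 3-aminophenyl gives an at least 2.5-fold higher number from compound 1 to compound 4 (0.39 log units; beyond the scatter), even though both groups hold one six-membered aromatic ring of carbon only. Compound 4 has only a limit, not a number: the limit of > 20000 nM in this assay, at which 1 of the 4 values shown sits.

The change both removes the amino nitrogen and adds a carbon link, and the compounds shown do not separate these two differences. From the compounds shown here alone, what a plain phenyl or a 3-aminobenzyl would give on this nitrogen stays open.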